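A Chloro Added to the Least Tolerated Compound

The compounds below may be only part of what the source reports. "The series", "measured", "known", "first", "only" and "open" are said of these compounds alone.

compound 1 `CCN(CC)CN1C(=O)/C(=N/NC(N)=S)c2cc(Cl)ccc21`: 78300 nM
compound 2 `CCN(CC)CN1C(=O)/C(=N/NC(=S)Nc2ccccc2)c2ccccc21`: 1600 nM
compound 3 `CCN(CC)CN1C(=O)/C(=N/NC(=S)Nc2ccc(C)cc2)c2ccccc21`: 200 nM

In an ADME assay on MDCK cells (Canis lupus familiaris) for cytotoxicity (a higher number here means that more compound is tolerated, a lower number that less compound is tolerated), compound 3 stands lowest of the three at 200 nM. Compound 2 lies nearest to it, and compound 1 lies furthest away. Compound 4 `CCN(CC)CN1C(=O)/C(=N/NC(=S)Nc2ccc(C)cc2)c2cc(Cl)ccc21` differs from compound 3 in one place, with chloro in place of hydrogen on an aromatic carbon.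

Among the compounds with values here, no measured pair isolates this change. Compound 1 also carries a chloro, but it differs from compound 3 in more than that one place, so the gap between their values cannot be read as a chloro step. Within the data shown here, the only measured step is an 8.0-fold lower number from compound 2 to compound 3 (0.90 log units; beyond the scatter), for methyl in place of hydrogen on an aromatic carbon. It shows that one small substituent can move the number beyond the scatter, but it gives no direction for chloro. No step beyond the scatter is therefore expected, although a shift of similar size either way remains possible.

The expected step is no change at the digits printed from compound 3 to compound 4 (within the scatter). Compound 4 is estimated at 200 nM, with an expected range of 50 nM to 800 nM.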

Compound 4, half-maximal cytotoxic concentration: 11300 nM
Compound 4: the middle estimate sits 57-fold (1.75 log units) below what was measured, outside the stated range (above it).
By their numbers in this assay, from the lowest: compound 3; then compound 2; then compound 4; then compound 1.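

In this assay, chloro in place of hydrogen on this aromatic carbon, part of a fused or bridged system of two rings, gives a 57-fold higher number from compound 3 to compound 4 (1.75 log units; beyond the scatter), the only step shown that raises the number. The earlier methyl step had shown only a fall, so this position can move the number strongly in the other direction. With chloro present in both compounds, 4-methylphenyl in place of hydrogen on the amide-type nitrogen still gives a 6.9-fold lower number from compound 1 to compound 4 (0.84 log units; beyond the scatter), and nothing measured here explains either step.

Going by these compounds, it remains open whether the chloro step would hold with the plain phenyl of compound 2. Whether fluoro, bromo, methoxy or a nitrile on the same aromatic carbon would raise the number as chloro does is also unresolved.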